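The compounds below may be only part of what the source reports. "The series", "measured", "known", "first", "only" and "open" are said of these compounds alone.

Compounds measured in a physicochemical assay for solubility, at pH 6.8; on this read-out higher numbers stand for higher solubility and lower numbers for lower solubility: compound 1 `O=C(Nc1ccn(-c2cn(Cc3cccc(C(F)(F)F)c3)cn2)c(=O)c1)c1cscn1`, < 0.16 ug/mL; compound 2 `Cc1cccc(C(C)(O)c2nc(-n3ccc(NC(=O)c4cscn4)cc3=O)c[nH]2)c1`, 63 ug/mL.

For compound 1 the value < 0.16 ug/mL is a limit of this assay, not a number, as the limit of < 0.16 ug/mL in this assay, at which 1 of the 2 values shown sits, records. Going by the values given here, compound 2 is therefore the only compound with a number in this assay. Compound 3 `Cc1ccc(C(C)(O)c2nc(-n3ccc(NC(=O)c4cscn4)cc3=O)c[nH]2)cc1` is not yet measured; it differs from compound 2 by 4-methylphenyl in place of 3-methylphenyl on a saturated chain carbon bound to an aromatic carbon, an oxygen on a saturated carbon and a saturated chain carbon. Among the compounds with values here, no step between measured compounds is available, so the data do not tell the size of such a change. The change is expected to move this assay by no more than the usual scatter, the expected step being a 1.1-fold lower number from compound 2 to compound 3 (0.02 log units; within the scatter). Compound 3 is estimated at 60 ug/mL, between 25 ug/mL and 150 ug/mL.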

Compound 3, solubility: 16 ug/mL
For compound 3 the middle estimate is 3.8-fold (0.57 log units) above the measured one, outside the stated range (below it).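

Replacing 1-hydroxy-1-(3-methylphenyl)ethyl with 1-hydroxy-1-(4-methylphenyl)ethyl gives a 3.9-fold lower number from compound 2 to compound 3 (0.60 log units; beyond the scatter) in this assay. Going by these compounds alone, this is the first step that can be read at this position, and it is a modest one, beyond the scatter: two compounds with the same atoms, differing only in where the methyl sits on the phenyl ring, do not read alike. Nothing measured here accounts for the step.

Still open, on these data alone, is how an unsubstituted phenyl would read in this assay at this position. Also open, as far as these compounds go, is what a methoxy group, an amine or a carboxylic acid on that ring would do in place of the methyl.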